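Hydroxyl and fluorine on the aryl group of compound 3

The source may hold more compounds than are shown below. What is called first, only, known or untested is meant among the compounds shown, and "the series" means these compounds.

In a functional assay on HT-29 cells (Homo sapiens) for cytotoxicity, read by MTT assay, with a stated time of 72 h (a higher number here means a weaker inhibitor, a lower number a stronger inhibitor), compound 1 `COc1ccc(OC)c(/C=N/NC(=O)Nc2ccc(Oc3ccnc(-c4nncn4CCN(C)C)c3)c(F)c2)c1` gives 2070 nM, and compound 2 `COc1ccc(/C=N/NC(=O)Nc2ccc(Oc3ccnc(-c4nncn4CCN(C)C)c3)c(F)c2)c(OC)c1` gives 1780 nM. Compound 3 `CN(C)CCn1cnnc1-c1cc(Oc2ccc(NC(=O)N/N=C/c3ccccc3)cc2F)ccn1` gives 1120 nM in this assay, and it stands within the scatter of both companions: a 1.8-fold lower number from compound 1 to compound 3 (0.27 log units; within the scatter) and a 1.6-fold lower number from compound 2 to compound 3 (0.20 log units; within the scatter). Compound 4 `CN(C)CCn1cnnc1-c1cc(Oc2ccc(NC(=O)N/N=C/c3ccc(O)c(F)c3)cc2F)ccn1` carries the change (3-fluoro-4-hydroxyphenyl in place of phenyl on a carbon with a double bond to nitrogen). Among the compounds with values here, the steps that bear on it are the exchanges of the aryl group on that same carbon, and both stayed within the scatter, so the account expects no step beyond the scatter in this assay for compound 4. This amounts to an expected step of a 1.1-fold lower number from compound 3 to compound 4 (0.05 log units; within the scatter). Compound 4 is therefore estimated at 1000 nM, with a range from 400 nM to 2500 nM.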

Compound 4, half-maximal inhibitory concentration: 3310 nM
Beside the measured number, compound 4's estimate is 3.3-fold (0.52 log units) below it; measured number outside the range, above it.
By their numbers in this assay, from the lowest: compounds 3, 2, 1 and 4 (each within the scatter of the next, the first and the last beyond it).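

In this assay, within the data shown here, the exchange of the aryl group on this carbon gives, with a 3.0-fold higher number from compound 3 to compound 4 (0.47 log units; beyond the scatter), the first step beyond the scatter at this position, on moving from phenyl to 3-fluoro-4-hydroxyphenyl. Measured against the dimethoxyphenyl compounds, the same group stays within the scatter, with a 1.9-fold higher number from compound 2 to compound 4 (0.27 log units; within the scatter) and a 1.6-fold higher number from compound 1 to compound 4 (0.20 log units; within the scatter), so compound 4 stands clearly apart only from compound 3. Nothing at hand accounts for this step. The compounds shown do not separate the hydroxyl from the fluorine, so it remains open whether either alone on the phenyl gives such a step. Also open, on these data alone, is what an amine or a carboxylic acid on that aryl group would give.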